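A few compounds are considered here, and "the series" means these few. Any claim that something is new, unique, unknown or untested is made for them only; others in the source may bear on it.

Compound 1 `COc1cc2c(cc1OC)C(=O)/C(=C/c1ccc(CN(C)Cc3ccccc3)c(O)c1)O2`: 17.8%
Compound 2 `COc1cc2c(cc1OC)C(=O)/C(=C/c1cccc(O)c1)O2`: 37%

Within the data shown here, in an assay on cells for inhibition of Amine oxidase [flavin-containing] B (Homo sapiens), read by fluorescence, with a stated time of 30 min, tested at 10 uM (a higher number here means more inhibition at the concentration tested (going by the name of the read-out), a lower number less inhibition), compound 2 gives the higher of the two numbers, and the only measured step, a number 19.2 percentage points higher from compound 1 to compound 2 (beyond the scatter), lies beyond the scatter. Compound 3 `COc1cc2c(cc1OC)C(=O)/C(=C/c1ccc(CN3CCCCC3)c(O)c1)O2` differs from compound 2 by (piperidin-1-yl)methyl in place of hydrogen on an aromatic carbon, which brings back a nitrogen-containing group of the kind whose removal made up that step. That step bears directly on the new change and was modest, so a decrease of similar size is expected, a number 15 percentage points lower from compound 2 to compound 3 (beyond the scatter). Compound 3 is therefore estimated to give 22%, in a range from 8% to 38%.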

Compound 3, a percentage reported as inhibition, at one concentration (the size of the read-out at that concentration, not a potency): 32%
Compound 3: the middle estimate sits 10 percentage points below what was measured; the measured number falls inside the stated range.
By their numbers in this assay, from the lowest: compound 1; then compounds 3 and 2 (each within the scatter of the next).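

In this assay, the step of a number 5 percentage points lower from compound 2 to compound 3 (within the scatter) shows that compound 2 and compound 3 cannot be told apart, so (piperidin-1-yl)methyl on this aromatic carbon, ortho to a hydroxy group, is accepted. The step of a number 14.2 percentage points higher from compound 1 to compound 3 (beyond the scatter) ties the lower number of compound 1 to benzyl(methyl)amino rather than to an amine at this place in general. No measurement here explains this difference. Going by these compounds, it remains open whether a smaller amine such as dimethylamino, or a morpholine ring, would track piperidin-1-yl or benzyl(methyl)amino.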